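A Sulfonamide Pair Tested Against a Mitochondrial Enzyme

The source may hold more compounds than are shown below. What is called first, only, known or untested is meant among the compounds shown, and "the series" means these compounds.

Going by the values given here, in an assay on isolated protein for inhibition of malate dehydrogenase, mitochondrial (Sus scrofa), with stated times of 45 min and 30 min (a higher number here means a weaker inhibitor, a lower number a stronger inhibitor), both compounds measured so far stop at the edge of what the test can see. Compound 1 `O=S(=O)(Nc1ccc2oc(-c3ccccc3)nc2c1)c1ccc(Cl)c(C(F)(F)F)c1` reaches only a limit of > 63000 nM. Compound 2 `O=S(=O)(Nc1ccc2oc(-c3ccccc3)nc2c1)c1ccccc1Cl` likewise gives only a limit of > 63000 nM. Compound 2 therefore stands at the same edge as every other value shown, as summed up by the limit of > 63000 nM in this assay, at which 2 of the 2 values shown sit, and no actual number for it is known. Compound 3 `Cc1cccc(S(=O)(=O)Nc2ccc3oc(-c4ccccc4)nc3c2)c1` is the next to be measured. It differs from compound 2 in one place: 3-methylphenyl in place of 2-chlorophenyl on a sulfonyl sulfur. Among the compounds with values here, with no measured step between compounds to draw on, no change beyond the usual scatter is expected, and the expected step is a step that the limit leaves unreadable from compound 2 to compound 3. Compound 3 is accordingly estimated at 80000 nM, with a range from 20000 nM to 300000 nM, and the outcome is most likely once more only a limit.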

Compound 3, half-maximal inhibitory concentration: > 63000 nM
Compound 3 gave a limit, no number; the forecaster's own chance of this, stated with the estimate: 85%; the middle value does not contradict the limit.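

Going by these compounds alone, compound 3 also gives only a limit, so no step from compound 2 to compound 3 can be read: the limit of > 63000 nM in this assay, at which 3 of the 3 values shown sit. The compounds shown leave open whether any of the three has a readable potency in this assay, and whether another group on the sulfonyl sulfur would give an actual number.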